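This account rests on a few compounds, and the source may have more. Where it says the series, first, only, none or still open, it means among the compounds named here.

Series notes. Compound 1 `COc1ccc(-c2c(C)nc3c(N4CC[C@@H](NC(=O)Nc5ccccc5)C4)cc(C)nn23)cc1OC` carries a phenylcarbamoyl on the amine nitrogen of the shared core. In an ADME assay on microsomes from liver (Homo sapiens) for metabolic stability, read by LC-MS, with NADPH named in the record, with a stated time of 60 min, tested at 1 uM, in the absence of a further agent (a lower number here means that less of the compound is left, a higher number that more of the compound is left), compound 1 returns only the assay's limit, > 95%. Compound 2 `COc1ccc(-c2c(C)nc3c(N4CC[C@@H](NS(=O)(=O)C(C)C)C4)cc(C)nn23)cc1OC` has isopropylsulfonyl in that place; in this assay compound 2 also reports a limit, > 95%. Compound 3 `COc1ccc(-c2c(C)nc3c(N4CC[C@@H](NS(=O)(=O)c5ccc(C)cc5)C4)cc(C)nn23)cc1OC` has (4-methylphenyl)sulfonyl there; in this assay compound 3 likewise gives a limit, > 95%. The steps a step that the two limits leave unreadable from compound 1 to compound 2, a step that the two limits leave unreadable from compound 1 to compound 3 and a step that the two limits leave unreadable from compound 2 to compound 3 stay unreadable because of the limit of > 95% in this assay, at which 3 of the 3 values shown sit. Compound 4 `COc1ccc(-c2c(C)nc3c(N4CC[C@@H](N=[N+]=[N-])C4)cc(C)nn23)cc1OC` differs from compound 3 by azido in place of ((4-methylphenyl)sulfonyl)amino on a saturated ring carbon. Among the measured compounds shown here, no measured step covers this change; the three values only show that every member so far reaches the limit. For compound 4 in this assay the estimate is 90%, range 68% to 99%. The step of a number at least 5 percentage points lower from compound 3 to compound 4 (that floor lies within the scatter) is expected to stay within the scatter.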

Compound 4, percent of the compound remaining: > 95%
Compound 4 ended at the assay's limit (the forecaster's own chance of this, stated with the estimate: 50%); at least 5 percentage points between middle value and limit.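

The steps to compound 4 from compound 1, compound 2 and compound 3 cannot be read in this assay: the limit of > 95% in this assay, at which 4 of the 4 values shown sit.

The compounds shown leave open whether any change at this place on the shared core gives a value clear of the limit.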